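This account rests on a few compounds, and the source may have more. Where it says the series, first, only, none or still open, it means among the compounds named here.

The measured compounds:
Compound 1, `CCCc1cc(N)c2cc(NC(=O)/C=C/c3ccc(C(C)(C)C)cc3)ccc2n1`, gives 910 nM.
Compound 2, `CCCc1cc(N2CCCC2)c2cc(NC(=O)/C=C/c3ccc(C(F)(F)F)cc3)ccc2n1`, gives 2800 nM.
Compound 3, `Nc1cc(C2CCCCC2)nc2ccc(NC(=O)/C=C/c3ccc(C(F)(F)F)cc3)cc12`, gives 96 nM.

These numbers come from a functional assay on HEK293 cells for activation of melanin-concentrating hormone receptor 1 (Homo sapiens), read by inositol phosphate accumulation; a lower number here means that less compound is needed, a higher number that more compound is needed for the effect. Among the three, compound 1 stands second highest. Its nearest neighbour is compound 2, whose number is higher by a margin beyond the usual scatter of this measurement; compound 3 sits furthest away, with a number well below that of compound 1, again beyond the scatter. Compounds 2 and 3 each differ from compound 1 in more than one place, so no single structural change can be read off from their values.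

Compound 4, `CCCc1cc(N)c2cc(NC(=O)/C=C/c3ccc(SC)cc3)ccc2n1`, has not yet been measured. It differs from compound 1 in one place only: methylsulfanyl in place of tert-butyl on an aromatic carbon. Within the data shown here, no pair of measured compounds shows an exchange of this kind, so there is no directly comparable step to lean on. The expectation for the step from compound 1 to compound 4 is therefore a change of modest size, with the direction uncertain, and an estimate that stays close to the value of compound 1 with a wide range around it. For compound 4 the estimated value is 1400 nM, expected to fall between 400 nM and 5000 nM, which corresponds to an expected step of a 1.5-fold higher number from compound 1 to compound 4 (0.19 log units; within the scatter).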

Compound 4, half-maximal effective concentration: 71 nM
For compound 4 the middle estimate is 20-fold (1.29 log units) above the measured one; the measured number lies below the stated range.
By their numbers in this assay, from the lowest: compounds 4 and 3 (each within the scatter of the next); then compound 1; then compound 2.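

Putting methylsulfanyl in place of tert-butyl on this aromatic carbon, para to a large group, brings a 13-fold lower number from compound 1 to compound 4 (1.11 log units; beyond the scatter) in this assay, so this position strongly influences the result. The exchange removes a branched group of four carbon atoms and brings in a group of two heavy atoms, one of them sulfur, with one hydrogen-bond acceptor, which shows that tert-butyl is not needed here for a low number. None of the data shown explains why this one exchange has so large an effect.

From the compounds shown here alone, it remains open whether the sulfur atom itself matters or whether a small group of similar size would serve equally well, a question that methoxy, with oxygen in place of sulfur, or ethyl, with carbon in its place, could help to settle on the same core. Going by these compounds, it is also open whether a longer chain on the sulfur, such as ethylsulfanyl, would keep the number as low as that of compound 4 or would lose part of the gain.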